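Replacing a Pyridylmethyl Amide Arm in an Ephrin Receptor Series

The source may report more compounds than this note shows. Statements on the series, on what has been measured and on what is new or still open speak of the compounds shown alone.

Compound 1 `Cc1cccc(Oc2ccnc(N3CCC[C@H]3C(=O)NCc3cccnc3)n2)c1` was tested in an assay on isolated protein for inhibition of Ephrin type-B receptor 4 (Homo sapiens), read by HTRF, tested at 10 uM; a lower number here means less inhibition, a higher number more inhibition at the concentration tested (going by the name of the read-out). In this assay compound 1 gives 0%, meaning no measurable inhibition at the tested concentration. Among the measured compounds shown here, compound 2 `Cc1cccc(Nc2ncnc3c2CN(C(=O)c2ccc(N(C)C)c4ccccc24)CC3)c1`, built on a different core, is the only other measured compound, and in this assay compound 2 gives 0%. Compound 1 therefore stands level with compound 2 at the digits shown, the two values lying within the usual scatter of such measurements, so neither can be said to differ from the other.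

Compound 3 `COC(=O)C(CO)NC(=O)[C@@H]1CCCN1c1nccc(Oc2cccc(C)c2)n1` has not yet been measured. It keeps the core of compound 1 and differs in one place: 2-hydroxy-1-(methoxycarbonyl)ethyl in place of (pyridin-3-yl)methyl on an amide-type nitrogen. For the measured compounds named here, no measured pair in this set shows what such a change does, so the expectation rests on compound 1 alone.

Because compound 1 gives 0%, compound 3 is expected to remain near the bottom of the scale. The expected step, a number 2 percentage points higher from compound 1 to compound 3 (within the scatter), is none beyond the scatter in either direction. Compound 3 is estimated at 2%, with a range from -8% to 15%.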

Compound 3, a percentage reported as inhibition, at one concentration (the size of the read-out at that concentration, not a potency): 0%
Compound 3: the middle estimate sits 2 percentage points above what was measured; measured number inside the range.
By their numbers in this assay, from the lowest: compounds 1, 2 and 3 (each within the scatter of the next).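

In this assay, putting 2-hydroxy-1-(methoxycarbonyl)ethyl in place of (pyridin-3-yl)methyl on the amide-type nitrogen gives no change at the digits printed from compound 1 to compound 3 (within the scatter). Among the compounds shown here, this is the first view of this position, and it shows that an open chain with no ring and an aromatic ring with a ring nitrogen, each of the same heavy-atom count, read alike: compound 1 gives 0% and compound 3 gives 0%. Nothing else measured here bears on the reason for this result.

With both compounds at the bottom of the scale, the step cannot say whether this position matters for inhibition, since compound 1 has no measurable inhibition to lose. Still open, as far as these compounds go, is whether any other group on this nitrogen would give a reading, such as a carboxylic acid in place of the methoxycarbonyl, or a longer chain ending in an amine.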